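A few compounds are considered here, and "the series" means these few. Any claim that something is new, unique, unknown or untested is made for them only; others in the source may bear on it.

The measured compounds, all read in a functional assay, with a stated time of 20 min (on this read-out higher numbers stand for weaker inhibition and lower numbers for stronger inhibition), are these. Compound 1 `CCOC(=O)c1cnn(-c2nc(-c3ccccc3Cl)c(C#N)c(=O)n2C)c1N` gives 78 ug/mL. Compound 2 `CCOC(=O)c1cnn(-c2nc(-c3cccs3)c(C#N)c(=O)n2C)c1N` gives 79 ug/mL. Compound 3 `CCOC(=O)c1cnn(-c2nc(-c3ccc(N(C)C)cc3)c(C#N)c(=O)n2C)c1N` gives 98 ug/mL.

These three numbers sit in a narrow band. Compound 3 lies at one edge of that band, yet the step of a 1.3-fold higher number from compound 1 to compound 3 (0.10 log units; within the scatter) and the step of a 1.2-fold higher number from compound 2 to compound 3 (0.09 log units; within the scatter) are both within the scatter, as is the step of a 1.0-fold higher number from compound 1 to compound 2 (0.01 log units; within the scatter), so the three compounds cannot be told apart on this read-out. Exchanging one aryl group for another at this position has so far left the number unchanged.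

Compound 4 `CCOC(=O)c1cnn(-c2nc(-c3cccc(OC)c3OC)c(C#N)c(=O)n2C)c1N` has not yet been measured. Its difference from compound 3 is 2,3-dimethoxyphenyl in place of 4-(dimethylamino)phenyl on an aromatic carbon. All three measured steps concern the same position and none reached beyond the scatter, so no step beyond the scatter is expected here either. The change from compound 3 to compound 4 is estimated as a 1.1-fold lower number from compound 3 to compound 4 (0.05 log units; within the scatter). Compound 4 is therefore expected to give about 88 ug/mL, with a likely range from 45 ug/mL to 175 ug/mL.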

Compound 4, half-maximal inhibitory concentration: 54 ug/mL
Compound 4: middle estimate off by 1.6-fold (0.21 log units), on the high side; the measured number falls inside the stated range.
By their numbers in this assay, from the lowest: compounds 4, 1, 2 and 3 (each within the scatter of the next).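

In this assay, placing 2,3-dimethoxyphenyl on this aromatic carbon, ortho to a cyano group, gives steps of a 1.8-fold lower number from compound 3 to compound 4 (0.26 log units; within the scatter) and of a 1.5-fold lower number from compound 2 to compound 4 (0.17 log units; within the scatter) and of a 1.4-fold lower number from compound 1 to compound 4 (0.16 log units; within the scatter) from the three earlier groups. Among these compounds, the position now holds four different aromatic groups, among them one carrying two methoxy groups, and no pair of compounds can be told apart on this read-out, so this exchange shows no more of a measurable effect than the earlier ones did. Nothing available bears on why the numbers fall as they do.

Going by these compounds, whether a group that is not aromatic at this position, such as morpholine, a carboxylic acid or a longer alkyl chain, would give a step beyond the scatter remains open. The shown compounds also leave open whether any change elsewhere on the shared core would move the number.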